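The compounds below may be only part of what the source reports. "The series", "measured", "known", "first", "only" and "open" are said of these compounds alone.

Measured compounds:

Compound 1, `O=C(NCCCCCCn1cc(-c2ccccc2)c2ccccc21)Oc1ccccc1`, in an assay on microsomes from brain (strain Sprague-Dawley) for inhibition of Fatty-acid amide hydrolase 1 (Rattus norvegicus), read by fluorescence and HPLC, with stated times of 10 min and 60 min (on this read-out lower numbers stand for stronger inhibition and higher numbers for weaker inhibition), compound 1 gives 4900 nM.
Compound 2, `O=C(NCCCCCn1ccc2ccccc21)Oc1cccnc1`, in this assay compound 2 gives 3.6 nM.
Compound 3, `O=C(NCCCCCCn1ncc2ccccc21)Oc1ccccc1`, in this assay compound 3 gives 920 nM.

Among these three, compound 2 stands lowest, and its gaps to compound 3 and to compound 1 both lie beyond the scatter, so within this set compound 2 is the most potent. Among the measured compounds shown here, the two other compounds differ from compound 2 in more than one place, so no single step between measured compounds can be read from them; they only show that the two phenoxy carbamates carry much higher numbers than compound 2.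

Compound 4, `O=C(NCCCCCn1ccc2ccccc21)Oc1ccccc1`, has not yet been tested in this assay. It differs from compound 2 in one place: phenyl in place of pyridin-3-yl on an oxygen next to a carbonyl group. Because compound 1 gives 4900 nM and compound 3 gives 920 nM while both carry the phenoxy group, a weakening step is expected here, of moderate size rather than one matching those gaps, as their other differences cannot be separated out. The expected step is an 8.3-fold higher number from compound 2 to compound 4 (0.92 log units; beyond the scatter). For compound 4 the estimated value in this assay is 30 nM, with a range from 5 nM to 300 nM.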

Compound 4, half-maximal inhibitory concentration: 94 nM
Compound 4: middle estimate off by 3.1-fold (0.50 log units), on the low side; the range from low to high includes it.
By their numbers in this assay, from the lowest: compound 2; then compound 4; then compound 3; then compound 1.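

With the chain and the core unchanged, putting phenyl in place of pyridin-3-yl on an oxygen next to a carbonyl group gives, in this assay, a 26-fold higher number from compound 2 to compound 4 (1.42 log units; beyond the scatter), a large step. Among the compounds shown here, this is the first reading of this position alone, and it shows that the one ring nitrogen of the pyridin-3-yl group, with the hydrogen-bond acceptor counted for that group, goes with much of the lower number of compound 2. Nothing at hand explains the size of this step.

The compounds shown leave open whether pyridin-2-yl, pyridin-4-yl or pyrimidin-5-yl on the same oxygen would behave like pyridin-3-yl, and what a methoxy group or a fluorine on the ring would do. They also leave open whether the step holds on another chain or core, as the other pairs differ in more than one place and their steps cannot be read.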